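Nitrophenyl thioureas with a benzyloxy-biaryl sulfonamide: cytotoxicity notes

This account rests on a few compounds, and the source may have more. Where it says the series, first, only, none or still open, it means among the compounds named here.

Three compounds have been measured in an ADME assay on HEK-293T cells (Homo sapiens) for cytotoxicity, read by CCK-8 assay, with a stated time of 48 h; on this read-out lower numbers stand for stronger inhibition and higher numbers for weaker inhibition:

compound 1 `O=[N+]([O-])c1ccc(NC(=S)NCCNS(=O)(=O)c2ccc(-c3ccccc3OCc3ccccc3)s2)cc1` gives 8900 nM
compound 2 `O=[N+]([O-])c1cccc(NC(=S)NCCNS(=O)(=O)c2ccc(-c3ccccc3OCc3ccccc3)s2)c1` gives 18300 nM
compound 3 `O=[N+]([O-])c1ccc(NC(=S)NCCNS(=O)(=O)c2ccc(-c3ccccc3OCc3cccc(O)c3)s2)cc1` gives only a limit of this assay, > 20000 nM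

Compound 1 and compound 2 share a core and differ by 3-nitrophenyl in place of 4-nitrophenyl on an amide-type nitrogen. The step of a 2.1-fold higher number from compound 1 to compound 2 (0.31 log units; beyond the scatter) is the one move in the series that ends on a measured number at both ends. Compound 3 carries the core of compound 1 changed by hydroxy in place of hydrogen on an aromatic carbon, and the step of an at least 2.2-fold higher number from compound 1 to compound 3 (0.35 log units; beyond the scatter) is known only as far as the limit allows, since compound 3 sits at the limit of > 20000 nM in this assay, at which 1 of the 3 values shown sits.

Compound 4 `O=[N+]([O-])c1cccc(NC(=S)NCCNS(=O)(=O)c2ccc(-c3ccccc3OCc3cccc(O)c3)s2)c1` has not yet been measured in this assay. It stands to compound 3 as compound 2 stands to compound 1: the change is 3-nitrophenyl in place of 4-nitrophenyl on an amide-type nitrogen, the same change that was made from compound 1 to compound 2, at the same place. The two cores differ by the hydroxy in place of hydrogen already described.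

From compound 3 to compound 4 a step that the limit leaves unreadable from compound 3 to compound 4 is expected, resting on the step from compound 1 to compound 2 carried over to the core of compound 3. Because compound 3 already sits at the limit of > 20000 nM in this assay, at which 1 of the 3 values shown sits, compound 4 is expected to return only a limit as well. The estimate for compound 4 is 42000 nM, with a range from 20000 nM to 90000 nM.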

Compound 4, half-maximal inhibitory concentration: 13800 nM
Beside the measured number, compound 4's estimate is 3.0-fold (0.48 log units) above it; measured number outside the range, below it.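

In this assay, 3-nitrophenyl in place of 4-nitrophenyl on the amide-type nitrogen gives an at least 1.4-fold lower number from compound 3 to compound 4 (0.16 log units; that floor lies within the scatter) on the hydroxy-bearing core, which runs opposite to the step on the core of compound 1, so the change does not carry over unaltered from one core to the other: the same change on two cores in this assay, a 2.1-fold higher number (0.31 log units; beyond the scatter) from compound 1 to compound 2 and an at least 1.4-fold lower number (0.16 log units; that floor lies within the scatter) from compound 3 to compound 4, at least 2.9-fold (0.47 log units) apart, beyond the scatter of two such steps The hydroxy change, which gives a 1.3-fold lower number from compound 2 to compound 4 (0.12 log units; within the scatter) with 3-nitrophenyl in place, likewise reads differently on the two nitrophenyl series: the same change on two cores in this assay, an at least 2.2-fold higher number (0.35 log units; beyond the scatter) from compound 1 to compound 3 and a 1.3-fold lower number (0.12 log units; within the scatter) from compound 2 to compound 4, at least 2.9-fold (0.47 log units) apart, beyond the scatter of two such steps Compound 3 gives only a limit of the assay, > 20000 nM, and the full size of the step from it stays unknown, while a single pair of cores sets no rule beyond these four compounds and gives no reason for the difference.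

Still open, going by these compounds, is whether the dependence between the two changes holds with a methoxy group in place of the hydroxy, or with a nitrile, an amine or a carboxylic acid in place of the nitro group. Also open, on these data alone, is how the series reads with a carbonyl in place of the thiocarbonyl, or with a longer chain in place of the one carrying the sulfonamide.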